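This account rests on a few compounds, and the source may have more. Where it says the series, first, only, none or still open, it means among the compounds named here.

- compound 1 `COC(=O)N1N=C(c2ccc(OC)cc2)CC1c1cc(OC)c(OC)c(OC)c1` gives 2590 nM
- compound 2 `COC(=O)N1N=C(c2cccc(O)c2)CC1c1cc(OC)c(OC)c(OC)c1` gives 1970 nM
- compound 3 `CCOc1cccc(C2=NN(C(=O)OC)C(c3cc(OC)c(OC)c(OC)c3)C2)c1` gives 4970 nM

In a functional assay on HeLa cells (Homo sapiens) for antiproliferative activity, read by MTT assay, with a stated time of 48 h (a higher number here means a weaker inhibitor of growth, a lower number a stronger inhibitor of growth), compound 3 gives 4970 nM and its two gaps differ: there is a 2.5-fold higher number from compound 2 to compound 3 (0.40 log units; beyond the scatter) and also a 1.9-fold higher number from compound 1 to compound 3 (0.28 log units; within the scatter) on the other side. The unmeasured compound 4 `COC(=O)N1N=C(c2ccc(O)cc2)CC1c1cc(OC)c(OC)c(OC)c1` carries 4-hydroxyphenyl in place of 3-ethoxyphenyl on a carbon with a double bond to nitrogen. Going by the values given here, the closest guide is a 2.5-fold higher number from compound 2 to compound 3 (0.40 log units; beyond the scatter) read backwards, although no measured compound has the 4-hydroxyphenyl group. Since a 1.3-fold lower number from compound 1 to compound 2 (0.12 log units; within the scatter) stays small, a return towards those two compounds is expected. The expected change in this assay is a 2.0-fold lower number from compound 3 to compound 4 (0.30 log units; within the scatter) and no larger. For compound 4 the estimated value is 2500 nM with an expected range from 1100 nM to 5500 nM as its upper end.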

Compound 4, concentration for 50% growth inhibition: 1140 nM
The estimate for compound 4 lay 2.2-fold (0.34 log units) above the measured number, within the range that was stated.
By their numbers in this assay, from the lowest: compounds 4, 2, 1 and 3 (each within the scatter of the next, the first and the last beyond it).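

In this assay, 4-hydroxyphenyl in place of 3-ethoxyphenyl gives a 4.4-fold lower number from compound 3 to compound 4 (0.64 log units; beyond the scatter), the largest step yet at this carbon with a double bond to nitrogen. Removing the methyl from the oxygen of 4-methoxyphenyl gives a 2.3-fold lower number from compound 1 to compound 4 (0.36 log units; beyond the scatter), so an oxygen-bound hydrogen can count here, although compound 2 did not separate from compound 1. Changing 3-hydroxyphenyl to 4-hydroxyphenyl gives a 1.7-fold lower number from compound 2 to compound 4 (0.24 log units; within the scatter), leaving the two hydroxyphenyl compounds unseparated. Nothing measured here explains these steps. Going by these compounds, whether an amine or a carboxylic acid in place of the hydroxyl would match it remains open.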